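Six-membered ring swap on the hydrazone of compound 3

The source may hold more compounds than are shown below. What is called first, only, known or untested is meant among the compounds shown, and "the series" means these compounds.

Compound 1 `C/C(=N\Nc1nc2ccccc2o1)c1ccccn1`: 23 nM
Compound 2 `C/C(=N\Nc1nc2ccccc2o1)c1cccnn1`: 1180 nM
Compound 3 `C/C(=N\Nc1nc2ccccc2o1)c1cnccn1`: 690 nM

In a functional assay on HeLa cells (Homo sapiens) for antiproliferative activity, read by sulforhodamine B assay (a higher number here means a weaker inhibitor, a lower number a stronger inhibitor), compound 3 stands second highest of the three numbers; its nearest neighbour is compound 2, at a gap within the scatter, and its furthest is compound 1, far below it. Compound 4 `C/C(=N\Nc1nc2ccccc2o1)c1cccnc1` differs from compound 3 in one place: pyridin-3-yl in place of pyrazin-2-yl on a carbon with a double bond to nitrogen. Going by the values given here, no measured step covers this exact exchange, so the pair is unknown. Among the compounds with values here, the steps that bear on the ring at this position, a 30-fold higher number from compound 1 to compound 3 (1.48 log units; beyond the scatter) and a 51-fold higher number from compound 1 to compound 2 (1.71 log units; beyond the scatter), were both large, while a 1.7-fold lower number from compound 2 to compound 3 (0.23 log units; within the scatter) was within the scatter. A change of the ring here has therefore moved the number either sharply or not at all, and compound 4 is expected to land near compound 3 or higher, with wide uncertainty. The estimate for compound 4 is 2000 nM (range 300 nM to 15000 nM), meaning an expected step of a 2.9-fold higher number from compound 3 to compound 4 (0.46 log units; beyond the scatter).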

Compound 4, half-maximal inhibitory concentration: > 100000 nM
Compound 4: a limit, no number (the forecaster's own chance of this, stated with the estimate: 20%); middle value at least 50-fold (1.69 log units) away from the limit.
By their numbers in this assay, from the lowest: compound 1; then compounds 3 and 2 (each within the scatter of the next). At a limit, above all of these: compound 4.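

In this assay compound 4 stands at a limit of the assay, not a number: (the limit of > 100000 nM in this assay, at which 1 of the 4 values shown sits). Pyridin-3-yl in this place gives steps larger than any seen before (an at least 140-fold higher number from compound 3 to compound 4 (2.16 log units; beyond the scatter)) (an at least 84-fold higher number from compound 2 to compound 4 (1.92 log units; beyond the scatter)) (an at least 4300-fold higher number from compound 1 to compound 4 (3.63 log units; beyond the scatter)). Compound 4 carries one ring hetero atom, as compound 1 does, yet the two lie furthest apart, while compound 2 and compound 3, with two, fall between them, so the count of ring nitrogens alone does not order these compounds.

As far as these compounds go, what a pyridin-4-yl or a plain phenyl ring would give on this carbon remains open.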